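This account rests on a few compounds, and the source may have more. Where it says the series, first, only, none or still open, it means among the compounds named here.

Of the compounds shown here, three have been measured so far in an assay on HL-60 cells for inhibition of cytochrome P450 26A1 (Homo sapiens), read by HPLC, using microsomes and NADPH, with a stated time of 30 min; on this read-out lower numbers stand for stronger inhibition and higher numbers for weaker inhibition. Compound 1, with structure `CCOC(=O)C(Cn1ccnc1)NC(=O)c1c(C)nn(-c2ccccc2)c1Cl`, gives 600 nM in this assay. Compound 2, `CCCOC(=O)C(Cn1ccnc1)NC(=O)c1c(C)nn(-c2ccccc2)c1Cl`, differs from compound 1 in one place: methyl in place of hydrogen on a saturated chain carbon, two bonds along the chain from an oxygen next to a carbonyl group. In this assay compound 2 gives 620 nM. The step of a 1.0-fold higher number from compound 1 to compound 2 (0.01 log units; within the scatter) shows that adding a methyl at that spot left the read-out where it was. Compound 3, `COC(=O)C(Cn1ccnc1)NC(=O)c1nc2ccccc2s1`, is built on another core; the difference between the two cores is not broken down here. In this assay compound 3 gives 410 nM, and all three numbers lie within the usual scatter of one another, so no order among them can be read from these data.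

Compound 4, `CCOC(=O)C(Cn1ccnc1)NC(=O)c1nc2ccccc2s1`, has not yet been measured. It differs from compound 3 by methyl in place of hydrogen on a saturated chain carbon bound to an oxygen next to a carbonyl group. Among the compounds with values here, this is the same kind of change as the one from compound 1 to compound 2, but not the same: there the methyl entered on a saturated chain carbon two bonds along the chain from an oxygen next to a carbonyl group, whereas here it enters on a saturated chain carbon bound to an oxygen next to a carbonyl group. Because the earlier step of a 1.0-fold higher number from compound 1 to compound 2 (0.01 log units; within the scatter) stayed within the scatter, a similarly small step is expected here as well, a 1.0-fold higher number from compound 3 to compound 4 (0.01 log units; within the scatter). Compound 4 is therefore estimated to give about 420 nM in this assay, most likely between 200 nM and 900 nM.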

Compound 4, half-maximal inhibitory concentration: 740 nM
Beside the measured number, compound 4's estimate is 1.8-fold (0.25 log units) below it; measured number inside the range.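

Setting a methyl in place of hydrogen on a saturated chain carbon bound to an oxygen next to a carbonyl group turns the methoxycarbonyl of compound 3 into the ethoxycarbonyl of compound 4, and in this assay this step (a 1.8-fold higher number from compound 3 to compound 4 (0.26 log units; within the scatter)) is too small to separate from the ordinary spread of repeated measurements. Set beside the methyl step on the other core, which sits two bonds along the chain from that oxygen, the result gives no sign that the two cores respond differently to this kind of change: the same change on two cores in this assay, a 1.0-fold higher number (0.01 log units; within the scatter) from compound 1 to compound 2 and a 1.8-fold higher number (0.26 log units; within the scatter) from compound 3 to compound 4, 1.7-fold (0.24 log units) apart, within the scatter of two such steps. This shows only that, in these two pairs, a single extra methyl on the ester chain leaves the read-out within the scatter; it does not show that the methyl has no influence on other cores, and it cannot rank the esters within either pair, since two pairs that differ in where the methyl enters are a thin basis for any rule.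

The compounds shown leave open what a clearly longer chain, such as hexyl, would give on the ester oxygen of either core. They also leave open whether a carboxylic acid or a simple amide in place of the ester would stay within the same range.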